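Replacing the aryl group on the ring nitrogen of compound 3

The source may report more compounds than this note shows. Statements on the series, on what has been measured and on what is new or still open speak of the compounds shown alone.

Compound 3 `COc1cc(NC(=O)Nc2cc(Nc3cc(Br)ccc3OC)ncn2)cc(OC)c1` gives 82.5% in a functional assay on PC-9 cells (Homo sapiens) for inhibition, read by MTT assay, with a stated time of 48 h, tested at 10 uM (a lower number here means less inhibition, a higher number more inhibition at the concentration tested (going by the name of the read-out)), the highest of the three numbers here. Compound 1 `CCc1ccc(Nc2cc(NC(=O)Nc3cc(OC)cc(OC)c3)ncn2)cc1` gives 78%, within the scatter of compound 3, while compound 2 `COc1cc(NC(=O)Nc2cc(Nc3cc(F)ccc3OC)ncn2)cc(OC)c1` gives 59.5%. Compound 4 `COc1cc(NC(=O)Nc2cc(Nc3cc(C)cc(F)c3)ncn2)cc(OC)c1` differs from compound 3 in one place: 3-fluoro-5-methylphenyl in place of 5-bromo-2-methoxyphenyl on a nitrogen on an aromatic ring. The earlier steps shown here that bear on it are a number 4.5 percentage points higher from compound 1 to compound 3 (within the scatter), a number 18.5 percentage points lower from compound 1 to compound 2 (beyond the scatter) and a number 23 percentage points higher from compound 2 to compound 3 (beyond the scatter). Within the data shown here, the only fluoro-bearing analogue, compound 2, stands lowest, so a modest fall is expected, a number 14.5 percentage points lower from compound 3 to compound 4 (beyond the scatter). Compound 4 is therefore estimated at 68%, between 50% and 85% in this assay.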

Compound 4, a percentage reported as inhibition, at one concentration (the size of the read-out at that concentration, not a potency): 64.5%
Compound 4: the middle estimate sits 3.5 percentage points above what was measured; low and high end bracket the measured number.
By their numbers in this assay, from the lowest: compounds 2 and 4 (each within the scatter of the next); then compounds 1 and 3 (each within the scatter of the next).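

In this assay the change to 3-fluoro-5-methylphenyl brings a number 18 percentage points lower from compound 3 to compound 4 (beyond the scatter) and a number 13.5 percentage points lower from compound 1 to compound 4 (beyond the scatter) but only a number 5 percentage points higher from compound 2 to compound 4 (within the scatter) here. On this nitrogen, the two fluoro-bearing aryl groups therefore sit together below the bromo and ethyl ones, with or without a methoxy, though only compound 2 and compound 4 carry this pattern. No measurement given explains it here. Still open, going by these compounds, is whether 3-bromo-5-methylphenyl would stay with compound 3, and whether a chloro or an amine on this ring would match fluoro or bromo.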